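From compound 3 to compound 4: one added methyl

The source may hold more compounds than are shown below. What is called first, only, known or untested is meant among the compounds shown, and "the series" means these compounds.

In an in vitro ADME assay on microsomes (Mus musculus) for metabolic stability (on this read-out lower numbers stand for a shorter-lived compound and higher numbers for a longer-lived compound), compound 1 `CC(=O)N1CCc2c(C)c3c(n2-c2ccc(C(N)=O)c(c2)N[C@@H](C)[C@H](C)C1)CC(C)(C)CC3=O` gives 0.0667 h and compound 3 `CC[C@H](N)C(=O)N1CCc2c(C)c3c(n2-c2ccc(C(N)=O)c(c2)N[C@@H](C)[C@H](C)C1)CC(C)(C)CC3=O` gives 0.383 h, the higher of these two numbers. That is a 5.7-fold higher number from compound 1 to compound 3 (0.76 log units; beyond the scatter). Compound 2 `Cc1c2c(n3c1CCN(C(=O)CN)C[C@@H](C)[C@H](C)Nc1cc-3ccc1C(N)=O)CC(C)(C)CC2=O` gives > 0.5 h, which is a limit and not a number. Its step from the first compound is an at least 7.4-fold higher number from compound 1 to compound 2 (0.87 log units; beyond the scatter).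

Compound 4 `Cc1c2c(n3c1CCN(C(=O)[C@@H](N)C(C)C)C[C@@H](C)[C@H](C)Nc1cc-3ccc1C(N)=O)CC(C)(C)CC2=O` differs from compound 3 by methyl in place of hydrogen on a saturated chain carbon bound to two saturated chain carbons. The closest measured change, ethyl in place of hydrogen, gave an at least 1.3-fold lower number from compound 2 to compound 3 (0.11 log units; that floor lies within the scatter), so no step beyond the scatter is expected here. The expected step is a 1.0-fold higher number from compound 3 to compound 4 (0.02 log units; within the scatter). Compound 4 is estimated at 0.4 h, with an expected range of 0.2 h to 0.8 h.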

Compound 4, half-life: 0.133 h
Compound 4: middle estimate off by 3.0-fold (0.48 log units), on the high side; measured number outside the range, below it.
By their numbers in this assay, from the lowest: compounds 1 and 4 (each within the scatter of the next); then compound 3. At a limit, above all of these: compound 2.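

The added methyl, which turns 1-aminopropyl into 1-amino-2-methylpropyl, is a small change with a clear cost: a 2.9-fold lower number from compound 3 to compound 4 (0.46 log units; beyond the scatter). It also removes the clear gain over the acetyl compound, leaving a 2.0-fold higher number from compound 1 to compound 4 (0.30 log units; within the scatter), so an amino group on this side chain does not by itself bring a longer half-life. The third step starts from a limit and not a number, so only its floor is known: an at least 3.7-fold lower number from compound 2 to compound 4 (0.57 log units; beyond the scatter).

Nothing shown explains this drop. On these data alone, whether branching or the added carbon matters stays open, and the unbranched 1-aminobutyl group would help separate the two.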